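Chain lengthening on a thione core: solubility notes

The compounds below may be only part of what the source reports. "The series", "measured", "known", "first", "only" and "open" are said of these compounds alone.

Measured so far:
compound 1 `CC(=O)n1c(=S)[nH]c2ccccc21` — 460000 nM
compound 2 `CCC(=O)n1c(=S)[nH]c2ccccc21` — 180000 nM
compound 3 `CCCCCCCCCC(=O)n1c(=S)oc2ccccc21` — 100000 nM

Among the compounds with values here, in a physicochemical assay for solubility (a lower number here means a less soluble compound, a higher number a more soluble compound), compound 2 stands second highest of the three numbers; compound 3, on a different core, gives 100000 nM, within the scatter of compound 2, while compound 1 sits higher by a 2.6-fold lower number from compound 1 to compound 2 (0.41 log units; beyond the scatter), the only single-change step measured and a modest one.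

Compound 4 `CCCCCC(=O)n1c(=S)[nH]c2ccccc21` differs from compound 2 by propyl in place of hydrogen on a saturated chain carbon, two bonds along the chain from a carbonyl carbon. Within the data shown here, only the step from compound 1 to compound 2 bears on this change, and compound 3 carries a longer chain on another core, so the comparison is indirect. A lowering step in this assay is expected, somewhat larger than a 2.6-fold lower number from compound 1 to compound 2 (0.41 log units; beyond the scatter) given the three carbons entering: compound 4 is estimated at a 3.0-fold lower number from compound 2 to compound 4 (0.48 log units; beyond the scatter), giving 60000 nM within 25000 nM to 150000 nM.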

Compound 4, solubility: 170000 nM
Beside the measured number, compound 4's estimate is 2.8-fold (0.45 log units) below it; measured number outside the range, above it.
By their numbers in this assay, from the lowest: compounds 3, 4 and 2 (each within the scatter of the next); then compound 1.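

In this assay, propyl in place of hydrogen at this place gives a 1.1-fold lower number from compound 2 to compound 4 (0.02 log units; within the scatter), so compound 2 and compound 4 cannot be told apart. The added chain carbons therefore do not repeat the earlier methyl step, a 2.6-fold lower number from compound 1 to compound 2 (0.41 log units; beyond the scatter), on the shared core. Butyl in place of hydrogen, on a saturated chain carbon bound to a carbonyl carbon, gives a 2.7-fold lower number from compound 1 to compound 4 (0.43 log units; beyond the scatter), a modest step beyond the scatter. As far as these compounds go, whether a longer chain, or an amine or carboxylic acid at its end, would shift the number on this core remains open. Nothing at hand explains why this step is so small.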